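Swapping the aryl group on the sulfonamide: compound 3 to compound 4

This account rests on a few compounds, and the source may have more. Where it says the series, first, only, none or still open, it means among the compounds named here.

Of the compounds shown here, three sharing one core have been measured in a functional assay on DLD-1 cells (Homo sapiens) for antiproliferative activity, read by CellTiter-Glo, with a stated time of 72 h; a higher number here means a weaker inhibitor, a lower number a stronger inhibitor. Compound 1 `CC1CCN(C2CCN(S(=O)(=O)c3cccc(-c4ccc(Cl)cc4)c3)CC2)CC1` gives 15 nM in this assay. Compound 2 `CC1CCN(C2CCN(S(=O)(=O)c3cnc(Cl)s3)CC2)CC1` gives 1800 nM. Compound 3 `CC1CCN(C2CCN(S(=O)(=O)c3cccnc3F)CC2)CC1` reaches only the limit of the assay, > 5000 nM, so no number is known for it. Among the measured compounds shown here, compound 3 therefore stands at the limit of > 5000 nM in this assay, at which 1 of the 3 values shown sits, the weak end of what this assay can report, and its step of an at least 2.7-fold higher number from compound 2 to compound 3 (0.44 log units; beyond the scatter) is the only measured step that touches it.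

Compound 4 `COc1cccc(S(=O)(=O)N2CCC(N3CCC(C)CC3)CC2)c1` differs from compound 3 in one place: 3-methoxyphenyl in place of 2-fluoropyridin-3-yl on a sulfonyl sulfur. For the measured compounds named here, no measured step covers exactly this change. Going by the values given here, the one step that bears on it, an at least 2.7-fold higher number from compound 2 to compound 3 (0.44 log units; beyond the scatter), shows that exchanging the ring on the sulfonyl sulfur can move the number beyond the scatter, and compound 1, with a carbon-only ring in the same position, shows that such a ring is compatible with a low number. The expectation for compound 4 is therefore a lower number than compound 3, a step of an at least 3.3-fold lower number from compound 3 to compound 4 (0.52 log units; beyond the scatter), estimated rather than measured. Compound 4 is expected to give about 1500 nM in this assay, with a likely range from 300 nM to 6000 nM.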

Compound 4, half-maximal inhibitory concentration: > 5000 nM
Compound 4 was reported as a limit (the forecaster's own chance of this, stated with the estimate: 30%); middle value at least 3.3-fold (0.52 log units) away from the limit.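

With methoxy in place of 4-chlorophenyl on an aromatic carbon there is an at least 330-fold higher number from compound 1 to compound 4 (2.52 log units; beyond the scatter): a carbon-only ring on the sulfonyl sulfur, present in both compounds, does not on its own give a low number. With 3-methoxyphenyl in place of 2-chloro-1,3-thiazol-5-yl on a sulfonyl sulfur there is an at least 2.7-fold higher number from compound 2 to compound 4 (0.44 log units; beyond the scatter), so this carbon-only ring also gives a higher number than that sulfur-containing ring. In this assay compound 4 gives > 5000 nM, which is a limit and not a number, and the step between compound 3 and compound 4 cannot be read, with both compounds now at the end of the measurable range: the limit of > 5000 nM in this assay, at which 2 of the 4 values shown sit.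

From the compounds shown here alone, how far compound 3 and compound 4 lie beyond that limit remains unknown, so the 2-fluoropyridin-3-yl and 3-methoxyphenyl rings cannot be ranked against each other. Also open, going by these compounds, is whether a smaller group than 4-chlorophenyl on that aromatic carbon, such as a chlorine atom, an amine or a carboxylic acid, would give a measurable number or whether the full second ring of compound 1 is needed.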